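The source may report more compounds than this note shows. Statements on the series, on what has been measured and on what is new or still open speak of the compounds shown alone.

In a functional assay on K562 cells (Homo sapiens), read by MTT assay, with a stated time of 72 h (a higher number here means a weaker inhibitor, a lower number a stronger inhibitor), compound 3 `CNc1ncnc2c1c(-c1cc3ccccc3o1)cn2[C@@H]1O[C@H](CO)[C@@H](O)[C@H]1O` gives > 20000 nM, which is a limit of the assay rather than a number. Compound 1 `CNc1ncnc2c1c(-c1cccs1)cn2[C@@H]1O[C@H](CO)[C@@H](O)[C@H]1O` likewise reaches only a limit, > 20000 nM. Compound 2 `CNc1ncnc2c1c(-c1ccoc1)cn2[C@@H]1O[C@H](CO)[C@@H](O)[C@H]1O` also stops at a limit, > 20000 nM. Compound 3 thus stands at the same ceiling as the two others, and none of the three can be ranked against another on the numbers shown. The steps a step that the two limits leave unreadable from compound 1 to compound 2, a step that the two limits leave unreadable from compound 1 to compound 3 and a step that the two limits leave unreadable from compound 2 to compound 3 all share one feature: the limit of > 20000 nM in this assay, at which 3 of the 3 values shown sit. Compound 4 `CNc1ncnc2c1c(I)cn2[C@@H]1O[C@H](CO)[C@@H](O)[C@H]1O` differs from compound 3 in one place: iodo in place of 1-benzofuran-2-yl on an aromatic carbon. For the measured compounds named here, no measured step bears on this change in a readable way, as every one of them is hidden behind the limit, so neither a size nor a direction can be taken from them for this assay. The estimate for compound 4 is 25000 nM, between 3000 nM and 100000 nM, and another limit is the expected outcome. The step from compound 3 to compound 4 is expected to be a step that the limit leaves unreadable from compound 3 to compound 4.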

Compound 4, half-maximal inhibitory concentration: > 100000 nM
Compound 4 was reported as a limit; the forecaster's own chance of this, stated with the estimate: 65%; at least 4.0-fold (0.60 log units) between middle value and limit.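

Compound 4 also stops at a limit, so its steps from compound 1, compound 2 and compound 3 cannot be read. The compounds shown leave open whether any group on this aromatic carbon changes the result in this assay; all four values are limits.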